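Cytotoxicity notes on the nitrophenylhydrazone benzoyl series

The compounds below may be only part of what the source reports. "The series", "measured", "known", "first", "only" and "open" are said of these compounds alone.

Compound 1 `CC(/C=N/Nc1ccc([N+](=O)[O-])cc1)=N\NC(=O)c1ccccc1` carries an unsubstituted benzoyl end on the shared core. In an ADME assay on J774 cells (Mus musculus, strain BALB/c) for cytotoxicity, read by resazurin assay, with a stated time of 72 h (on this read-out higher numbers stand for lower toxicity in this test and lower numbers for higher toxicity in this test), compound 1 gives > 100000 nM, which is a limit of the assay rather than a number. Compound 2 `CC(/C=N/Nc1ccc([N+](=O)[O-])cc1)=N\NC(=O)c1ccccc1F` adds fluoro in place of hydrogen on an aromatic carbon. In this assay compound 2 gives > 100000 nM, again a limit. The step that the two limits leave unreadable from compound 1 to compound 2 therefore cannot be read. Compound 3 `CC(/C=N/Nc1ccc([N+](=O)[O-])cc1)=N\NC(=O)c1ccc(C(F)(F)F)cc1` carries trifluoromethyl in place of hydrogen on an aromatic carbon, and in this assay compound 3 gives 78700 nM. For the measured compounds named here, this is the only number among the three values shown, so compound 3 stands as the one member with a readable value. The step of an at least 1.2-fold lower number from compound 1 to compound 3 (0.10 log units; that floor lies within the scatter) is small and only a floor because of the limit of > 100000 nM in this assay, at which 2 of the 3 values shown sit. Compound 4 `CC(/C=N/Nc1ccc([N+](=O)[O-])cc1)=N\NC(=O)c1ccc([N+](=O)[O-])cc1` is the next member: nitro in place of trifluoromethyl on an aromatic carbon. Going by the values given here, the only measured step bearing on it is an at least 1.2-fold lower number from compound 1 to compound 3 (0.10 log units; that floor lies within the scatter), and that is within the scatter; the change from compound 3 to compound 4 exchanges one group for another there, with no measured step of its own kind. No step beyond the scatter is therefore expected in this assay, and the value may again fall back to the limit. Compound 4 is expected to give 90000 nM, in the range 40000 nM to 200000 nM. The expected step of a 1.1-fold higher number from compound 3 to compound 4 (0.06 log units; within the scatter) lies within the scatter.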

Compound 4, half-maximal cytotoxic concentration: > 100000 nM
Compound 4: no number, only a limit; the forecaster's own chance of this, stated with the estimate: 45%; at least 1.1-fold (0.04 log units) between middle value and limit.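

In this assay, nitro in place of trifluoromethyl on an aromatic carbon, para to a large group, gives an at least 1.2-fold higher number from compound 3 to compound 4 (0.10 log units; that floor lies within the scatter), so this exchange can be read only as a floor. For the compounds shown here, the earlier compounds showed only replacements of hydrogen on the aromatic ring; this is the first exchange of one substituent for another at this place, and with nitro there compound 4 is a limit, which leaves compound 3 as the only member with a number. The steps from compound 1 and from compound 2 to compound 4 cannot be read, and the series gives no ranking of its members because the values collect at one ceiling: the limit of > 100000 nM in this assay, at which 3 of the 4 values shown sit.

Whether trifluoromethyl in compound 3 marks a real difference from the other members remains open, as no step shown is beyond the scatter. Also open, from the compounds shown here alone, is whether an amine, a carboxylic acid or a longer chain at this place would give a number clearly under the limit in this assay.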